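This account rests on a few compounds, and the source may have more. Where it says the series, first, only, none or still open, it means among the compounds named here.

Measured so far:
compound 1, `COc1cc(N2CCN(C(=O)N[C@@H](C)c3cccc4ccccc34)CC2)ccc1-n1cc(C)nn1`, 230 mL.min-1.g-1
compound 2, `COc1cc(N2CCN(C(=O)N[C@@H](C)c3cccc4ccccc34)CC2)ccc1-n1cnc(C)n1`, 110 mL.min-1.g-1

Both were tested in an ADME assay on microsomes from liver (Rattus norvegicus) for metabolic stability, read by LC-MS; a higher number here means faster removal of the compound, a lower number slower removal. Going by the values given here, compound 2 holds the lowest of the two numbers; the only measured step, a 2.1-fold lower number from compound 1 to compound 2 (0.32 log units; beyond the scatter), separates it from compound 1. Compound 3, `COc1cc(N2CCN(C(=O)N[C@@H](C)c3cccc4ccccc34)CC2)ccc1-n1cnc(C)c1`, is not yet measured; it carries 4-methyl-1H-imidazol-1-yl in place of 3-methyl-1H-1,2,4-triazol-1-yl on an aromatic carbon. Among the compounds with values here, no measured step swaps a ring with three hetero atoms for one with two, so the step from compound 1 to compound 2 guides only loosely. A small step, a 1.4-fold higher number from compound 2 to compound 3 (0.13 log units; within the scatter), is expected for compound 3, likely within the scatter. Compound 3 is estimated at 150 mL.min-1.g-1, from 60 mL.min-1.g-1 to 350 mL.min-1.g-1.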

Compound 3, intrinsic clearance in microsomes: 150 mL.min-1.g-1
Compound 3: the middle estimate sits on the measured number at the digits printed; the range from low to high includes it.
By their numbers in this assay, from the lowest: compounds 2, 3 and 1 (each within the scatter of the next, the first and the last beyond it).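

At this position, ortho to a methoxy group, a ring with 2 hetero atoms in place of 3 gives a 1.4-fold higher number from compound 2 to compound 3 (0.13 log units; within the scatter) and a 1.5-fold lower number from compound 1 to compound 3 (0.19 log units; within the scatter) in this assay. The 4-methyl-1H-imidazol-1-yl of compound 3 therefore cannot be told apart from either triazole, although compound 1 and compound 2 are separated beyond the scatter. Nothing at hand explains this result.

Still open, going by these compounds, is whether an amine, a carboxylic acid or a longer chain in place of these methyl-bearing rings would shift the clearance beyond the scatter.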